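A few compounds are considered here, and "the series" means these few. Any claim that something is new, unique, unknown or untested is made for them only; others in the source may bear on it.

Working notes on a small series read in a functional assay on PANC-1 cells (Homo sapiens) for cytotoxicity, read by WST assay, with a stated time of 24 h; a higher number here means a weaker inhibitor, a lower number a stronger inhibitor. Compound 1 (`O=C(/C=C/CCCCCCc1ccccc1)N1CCCCCC1`) gives > 100000 nM, which is a limit of the assay and not a number. Compound 2 (`O=C(CCCCCCc1ccccc1)N1CCCCC1`) gives > 100000 nM, again a limit and not a number. Compound 3 (`O=C(CCCCCCCCc1ccc(O)cc1)N1CCCCC1`) gives > 100000 nM, also a limit only. Among the compounds with values here, the series so far amounts to the limit of > 100000 nM in this assay, at which 3 of the 3 values shown sit. Within the data shown here, no order can be read among compound 1, compound 2 and compound 3, and no measured pair differs in one place, so there is no measured step to scale from.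

Compound 4 (`O=C(CCCCCCCCc1ccc(Cl)cc1)N1CCCCC1`) keeps the structure of compound 3 except for one substituent: chloro in place of hydroxy on an aromatic carbon. This is chloro in place of hydroxy on an aromatic carbon, para to a large group, or 4-hydroxyphenyl to 4-chlorophenyl.

No step beyond the scatter is expected in this assay, in either direction, because compound 3 sits at the limit of > 100000 nM. The expected step is a number no higher from compound 3 to compound 4 (the limit leaves the size open). A report as a limit is again the expected outcome, with a measurable number possible but less likely. The estimate for compound 4 is 100000 nM, with an expected range of 50000 nM to 200000 nM.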

Compound 4, half-maximal inhibitory concentration: 65500 nM
Estimate against measurement, compound 4: 1.5-fold (0.18 log units) above, and the stated range covers the measured number.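

In this assay, within the data shown here, compound 4 gives 65500 nM, the first measured number, so chloro in place of hydroxy on this aromatic carbon, para to a large group, gives a read-out inside the range of the assay. Compound 3 gives > 100000 nM, which is a limit of the assay and not a number. The change therefore reads only as an at least 1.5-fold lower number from compound 3 to compound 4 (0.18 log units; that floor lies within the scatter), so its true size stays unknown and the single number rests on a series otherwise held at the ceiling: the limit of > 100000 nM in this assay, at which 3 of the 4 values shown sit.

On these data alone, whether other groups at this place, such as fluoro, bromo, methoxy, an amine or a carboxylic acid, also give a measurable number stays open, as does any order among them and chloro. Equally open, as far as these compounds go, is whether chloro on the aromatic ring of the core of compound 2, with its different chain, or of the core of compound 1 would also give a number rather than a limit.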